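The compounds below may be only part of what the source reports. "The series", "measured", "known", "first", "only" and "open" are said of these compounds alone.

Of the compounds shown here, three built on one shared core have been measured, and they differ only in the aryl group attached to one aromatic carbon. Compound 1 `CCOc1nc(-c2cc3ccccc3o2)cc(-c2ccc(OC)cc2OC)c1C#N` gives 488000 nM in a functional assay on aorta (strain Wistar) for inhibition, with Thoracic aorta (Rattus norvegicus) as the target; on this read-out lower numbers stand for stronger inhibition and higher numbers for weaker inhibition. Compound 2 `CCOc1nc(-c2cc3ccccc3o2)cc(-c2ccc(C)o2)c1C#N` gives 417000 nM in this assay, and compound 3 `CCOc1nc(-c2cc3ccccc3o2)cc(-c2cn(C)c3ccccc23)c1C#N` gives 327000 nM. Compound 3 holds the lowest of the three numbers, but the steps between them are small: a 1.2-fold lower number from compound 1 to compound 2 (0.07 log units; within the scatter), a 1.5-fold lower number from compound 1 to compound 3 (0.17 log units; within the scatter) and a 1.3-fold lower number from compound 2 to compound 3 (0.11 log units; within the scatter), each within the scatter, so none of the three can be called stronger or weaker than another.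

Compound 4 `CCOc1nc(-c2cc3ccccc3o2)cc(-c2cn(CC)c3ccccc23)c1C#N` differs from compound 3 by methyl in place of hydrogen on a saturated chain carbon bound to an aromatic nitrogen. For the measured compounds named here, none of the measured steps touches this part of the molecule; each of them exchanges the whole aryl group on the core, and even those exchanges left the number within the scatter. Going by the values given here, nothing among the measured compounds therefore points to a step in this assay in either direction, and the expected step is a 1.0-fold higher number from compound 3 to compound 4 (0.00 log units; within the scatter), nothing beyond the scatter. Compound 4 is accordingly estimated at 330000 nM, with a range from 130000 nM to 800000 nM.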

Compound 4, half-maximal inhibitory concentration: 358000 nM
Compound 4: middle estimate off by 1.1-fold (0.04 log units), on the low side; the measured number falls inside the stated range.
By their numbers in this assay, from the lowest: compounds 3, 4, 2 and 1 (each within the scatter of the next).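

Methyl in place of hydrogen on a saturated chain carbon bound to an aromatic nitrogen, which cut one bond further out reads as methyl to ethyl, gives a 1.1-fold higher number from compound 3 to compound 4 (0.04 log units; within the scatter) in this assay, so this position carries the added carbon with no step that can be told from the scatter. The earlier steps each exchanged a whole aryl group on the shared core, whereas this one is a small change within one of those groups, and it too leaves all four compounds within the scatter of the next in the order of their numbers, with none of them shown to be stronger or weaker. No measured evidence is available that would explain this result at this position.

From the compounds shown here alone, whether a longer chain such as propyl or butyl at this position, or an amine or a carboxylic acid carried on the chain, would give a step beyond the scatter remains open. Every step among the compounds shown lies within the scatter, so they do not reveal which change on the shared core, if any, would move the number in this assay.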